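Fluorine-to-hydrogen step on the benzylamine arm

The source may report more compounds than this note shows. Statements on the series, on what has been measured and on what is new or still open speak of the compounds shown alone.

Working notes on the series. Compound 1 `Cc1c(CNCc2ccccc2)cc(-c2ccc(Cl)cc2)n1-c1ccc(Cl)cc1` carries the shared core with a second chlorophenyl group; in an ADME assay on RAW264.7 cells (Mus musculus) for cytotoxicity, read by trypan blue exclusion, with a stated time of 48 h (on this read-out lower numbers stand for stronger inhibition of growth and higher numbers for weaker inhibition of growth), compound 1 gives "not determined" (no result reported), so it has no number to set against the others. Compound 2 `Cc1cc(CNCc2ccc(F)cc2)c(C)n1-c1ccc(Cl)cc1` is the only member with a number: in this assay compound 2 gives 26 ug/mL, so it stands alone and no ranking within the series is possible on the numbers shown. Compound 3 `Cc1cc(CNCc2ccccc2)c(C)n1-c1ccc(Cl)cc1` has not yet been run in this assay and differs from compound 2 in one place: hydrogen in place of fluoro on an aromatic carbon. Going by the values given here, no measured pair shows what this change does. A single fluorine removed from the 4-fluorobenzyl group is a small change by the count above, so the step in this assay is expected to be small and within the usual scatter, with no set direction. Compound 3 is therefore estimated at 30 ug/mL with a range of 12 ug/mL to 70 ug/mL. That expectation corresponds to a step of a 1.2-fold higher number from compound 2 to compound 3 (0.06 log units; within the scatter).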

Compound 3, concentration for 50% growth inhibition: 5.5 ug/mL
For compound 3 the middle estimate is 5.5-fold (0.74 log units) above the measured one, outside the stated range (below it).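

In this assay, the fluoro on the aromatic carbon para to a large group proves not to be a silent substituent: a 4.7-fold lower number from compound 2 to compound 3 (0.67 log units; beyond the scatter) is a step beyond the scatter, towards stronger inhibition of growth. This gives the series its first measured pair and shows that the read-out responds to a single-atom change on the benzylamine arm, with the plain benzyl group ahead of the 4-fluorobenzyl group. Nothing available explains the size or direction of this step.

Going by these compounds, the step rests on this one pair, so it remains open whether a chloro, methoxy or nitrile group in the same place would give a number closer to compound 2 or to compound 3. Also open, on these data alone, is whether the same step would appear on the core of compound 1, with its second chlorophenyl group.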